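The source may report more compounds than this note shows. Statements on the series, on what has been measured and on what is new or still open speak of the compounds shown alone.

Compound 1 `Cc1cc(NC(=O)Cn2cc(-c3ccc(Cl)cc3)nn2)no1` gives 1910 nM in a functional assay on BMDM cells (Mus musculus, strain C57BL/6) for inhibition, with a stated time of 2 days; on this read-out lower numbers stand for stronger inhibition and higher numbers for weaker inhibition. Compound 2 `COc1ccc(-c2cn(CC(=O)Nc3cc(C)on3)nn2)cc1` changes one group on the same core. In this assay compound 2 reaches only > 30000 nM, which is a limit of the measurement and not a number. The step between them is an at least 15-fold higher number from compound 1 to compound 2 (1.19 log units; beyond the scatter), a large loss of inhibition. Compound 2 therefore stands at the limit (the limit of > 30000 nM in this assay, at which 1 of the 2 values shown sits), the weaker end of what the assay can report. Compound 3 `C#Cc1ccc(-c2cn(CC(=O)Nc3cc(C)on3)nn2)cc1` takes the next step: ethynyl in place of methoxy on an aromatic carbon The methoxy that leaves here is the same group whose arrival marked the large step from compound 1 to compound 2, so that step bears on this one. Ethynyl is not chloro, so no full return to the number of compound 1 is assumed, but the step is expected to run toward lower numbers in this assay. For compound 3 the estimate is 4000 nM, between 1000 nM and 20000 nM, which means an expected step of an at least 7.5-fold lower number from compound 2 to compound 3 (0.87 log units; beyond the scatter).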

Compound 3, half-maximal inhibitory concentration: > 30000 nM
Compound 3: no number, only a limit; the forecaster's own chance of this, stated with the estimate: 30%; middle value at least 7.5-fold (0.87 log units) from the limit.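

Compound 3 stands at a limit of this assay and not at a number, as compound 2 does, so the step between these two compounds cannot be read. With ethynyl in place of chloro on the aromatic carbon para to a large group, the result is an at least 15-fold higher number from compound 1 to compound 3 (1.19 log units; beyond the scatter), which means that methoxy is no longer the only replacement for chloro that loses a large part of the inhibition. Among the three groups shown at this place, only chloro gives a readable number, and the other two cannot be ranked against each other: the limit of > 30000 nM in this assay, at which 2 of the 3 values shown sit.

From the compounds shown here alone, how much inhibition, if any, compound 2 and compound 3 retain stays unknown. Going by these compounds, it also stays open whether bromo, a methyl group or an amine at this place would give a readable number, and how that number would compare with compound 1.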